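Dimethylamino in Place of Fluoro on Compound 2

The source may report more compounds than this note shows. Statements on the series, on what has been measured and on what is new or still open speak of the compounds shown alone.

Compound 2 `Cc1cccc2c1N(CC(=O)O)C/C(=C\c1ccc(F)cc1)C2=O` gives 22.9% in an assay on HL-60 cells for inhibition of glutathione S-transferase P (Homo sapiens), read by spectrophotometry, tested at 20 uM; on this read-out lower numbers stand for less inhibition and higher numbers for more inhibition at the one concentration tested (going by the name of the read-out). Of the three measured compounds it stands second highest: compound 1 `CCOc1ccc(/C=C2\CN(CC(=O)O)c3c(C)cccc3C2=O)cc1` gives 42.4%, and compound 3 `Cc1cc(C)cc(/C=C2\CN(CC(=O)O)c3c(C)cccc3C2=O)c1` gives 17.5%. The step from compound 1 to compound 2, fluoro in place of ethoxy on an aromatic carbon, is a number 19.5 percentage points lower from compound 1 to compound 2 (beyond the scatter), beyond the scatter. The step from compound 2 to compound 3 is a number 5.4 percentage points lower from compound 2 to compound 3 (within the scatter), within the scatter.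

Compound 4 `Cc1cccc2c1N(CC(=O)O)C/C(=C\c1ccc(N(C)C)cc1)C2=O` differs from compound 2 in one place: dimethylamino in place of fluoro on an aromatic carbon. The step that bears on this change is the one at the same aromatic carbon, where a group with one acceptor was lost and the number fell by a number 19.5 percentage points lower from compound 1 to compound 2 (beyond the scatter). Since compound 4 again carries a group with one acceptor at that carbon, the change is expected to recover part of that loss, so the step from compound 2 to compound 4 is expected to be a number 12.1 percentage points higher from compound 2 to compound 4 (beyond the scatter) in this assay. Compound 4 is therefore estimated to give 35%, with a range from 20% to 50%.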

Compound 4, a percentage reported as inhibition, at one concentration (the size of the read-out at that concentration, not a potency): 13.2%
Estimate against measurement, compound 4: 21.8 percentage points above; the measured number lies below the stated range.
By their numbers in this assay, from the lowest: compounds 4, 3 and 2 (each within the scatter of the next); then compound 1.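

In this assay, dimethylamino in place of fluoro gives a step (a number 9.7 percentage points lower from compound 2 to compound 4 (within the scatter)), so this change does not separate the two groups at this aromatic carbon. Replacing ethoxy with dimethylamino gives a much clearer step (a number 29.2 percentage points lower from compound 1 to compound 4 (beyond the scatter)), which shows that a group with one hydrogen-bond acceptor at this carbon is not enough to keep the number of compound 1. Among the three groups compared here, only ethoxy stands apart, and dimethylamino, despite its acceptor, falls with fluoro, which has none; no measurement here explains this.

On these data alone, whether the higher number of compound 1 depends on the ether oxygen, the ethyl chain or both remains open. Methoxy, propoxy or a hydroxyl group at this carbon would bear on that question.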